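This account rests on a few compounds, and the source may have more. Where it says the series, first, only, none or still open, it means among the compounds named here.

Measured compounds:
compound 1 `O=C(Nc1nc2ccc([N+](=O)[O-])cc2s1)c1ccc(C(F)(F)F)cc1` gives 1.89 ug/mL
compound 2 `COc1cccc2sc(NC(=O)c3ccc(C(F)(F)F)cc3)nc12` gives > 10 ug/mL, which is a limit of the assay
compound 3 `Cc1cc(C)c2sc(NC(=O)c3ccc(C#N)cc3)nc2c1` gives 0.48 ug/mL

In a functional assay on MDA-MB-231 cells (Homo sapiens) for antiproliferative activity, read by sulforhodamine B assay (on this read-out higher numbers stand for weaker inhibition of growth and lower numbers for stronger inhibition of growth), compound 3 holds the lowest of the two numbers given; the nearest is compound 1, whose value sits higher by an amount beyond the scatter. The value of compound 2 is only a limit (the limit of > 10 ug/mL in this assay, at which 1 of the 3 values shown sits), so it cannot be placed. Compound 4 `Cc1ccc(C(=O)Nc2nc3cc(C)cc(C)c3s2)cc1` is not yet measured. It differs from compound 3 by methyl in place of cyano on an aromatic carbon. Among the measured compounds shown here, no measured pair shows this change, so the expected step from compound 3 to compound 4 in this assay is a 3.1-fold higher number from compound 3 to compound 4 (0.49 log units; beyond the scatter), estimated as a modest loss. Compound 4 is therefore expected to give about 1.5 ug/mL, within a range from 0.4 ug/mL to 6 ug/mL.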

Compound 4, concentration for 50% growth inhibition: 0.44 ug/mL
Beside the measured number, compound 4's estimate is 3.4-fold (0.53 log units) above it; low and high end bracket the measured number.
By their numbers in this assay, from the lowest: compounds 4 and 3 (each within the scatter of the next); then compound 1. At a limit, above all of these: compound 2.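

On the dimethyl-substituted shared core, putting methyl in place of cyano, para to a large group, gives a 1.1-fold lower number from compound 3 to compound 4 (0.04 log units; within the scatter) in this assay. In this one pair, the cyano group is therefore not needed to keep the growth inhibition seen with compound 3. Nothing measured here explains why the two groups read alike.

As far as these compounds go, whether an amine or a carboxylic acid at this place would read the same remains open. From the compounds shown here alone, it is also open whether the finding carries over to the cores of compound 1 and compound 2.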